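The source may report more compounds than this note shows. Statements on the series, on what has been measured and on what is new or still open speak of the compounds shown alone.

Compound 1 `COc1cccc(S(=O)(=O)Nc2ccc3oc(-c4ccccc4)nc3c2)c1` gives 63000 nM in an ADME assay on HEK293 cells (Homo sapiens) for cytotoxicity, read by resazurin assay, with a stated time of 48 h; a lower number here means that less compound is tolerated, a higher number that more compound is tolerated. Compound 2 `COc1ccc(S(=O)(=O)Nc2ccc3oc(-c4ccccc4)nc3c2)cc1` gives 91000 nM in this assay. For compound 3 `COc1ccc(S(=O)(=O)Nc2ccc(-c3nc4ccccc4o3)cc2)cc1` this assay reports a limit rather than a number, > 100000 nM.

Compounds 1 and 2 share one core and differ in one place: 3-methoxyphenyl in place of 4-methoxyphenyl on a sulfonyl sulfur. That change made a 1.4-fold lower number from compound 2 to compound 1 (0.16 log units; within the scatter). Compound 4 `COc1cccc(S(=O)(=O)Nc2ccc(-c3nc4ccccc4o3)cc2)c1` carries the same change on the core of compound 3: 3-methoxyphenyl in place of 4-methoxyphenyl on a sulfonyl sulfur. How the core of compound 2 differs from that of compound 3 is not broken down here. The reading for compound 3 sits at the limit of > 100000 nM in this assay, at which 1 of the 3 values shown sits. Because the measured step of a 1.4-fold lower number from compound 2 to compound 1 (0.16 log units; within the scatter) stayed within the scatter, the expected step here is also small, a number no higher from compound 3 to compound 4 (the limit leaves the size open). Compound 4 is therefore estimated at 100000 nM, between 55000 nM and 200000 nM, and this assay may again report only a limit.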

Compound 4, half-maximal cytotoxic concentration: > 100000 nM
Compound 4: only a limit was reported (the forecaster's own chance of this, stated with the estimate: 60%); the middle value sits exactly at the limit.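

Compound 3 and compound 4 both give only a limit, so no step can be read between them, because both sit at the same point: the limit of > 100000 nM in this assay, at which 2 of the 4 values shown sit.

The compounds shown leave open whether 3-methoxyphenyl in place of 4-methoxyphenyl on a sulfonyl sulfur changes the tolerated concentration on the core of compound 3.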